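The source may hold more compounds than are shown below. What is called first, only, known or untested is meant among the compounds shown, and "the series" means these compounds.

Three compounds of the shared core have numbers in a functional assay on SAOS-2 cells (Homo sapiens) for antiproliferative activity, read by MTT assay, with a stated time of 72 h; a higher number here means a weaker inhibitor, a lower number a stronger inhibitor. Compound 1 `O=C(C1=C(O)C(=O)N(CCCn2ccnc2)C1c1ccc(Br)cc1)c1ccccc1` gives 31600 nM. Compound 2 `CC(C)OC1=C(C(=O)c2ccccc2)C(c2ccc(Br)cc2)N(CCCn2ccnc2)C1=O` gives 23000 nM. Compound 3 `O=C(C1=C(Nc2ccccc2)C(=O)N(CCCn2ccnc2)C1c1ccc(Br)cc1)c1ccccc1` gives 24400 nM. All three steps between them lie within the scatter: a 1.4-fold lower number from compound 1 to compound 2 (0.14 log units; within the scatter), a 1.3-fold lower number from compound 1 to compound 3 (0.11 log units; within the scatter) and a 1.1-fold higher number from compound 2 to compound 3 (0.03 log units; within the scatter). Compound 3 therefore holds the second highest of the three numbers, with compound 2 nearest and compound 1 furthest, but nothing separates the three beyond the scatter.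

Compound 4 `O=C(C1=C(Nc2ccc(I)cc2)C(=O)N(CCCn2ccnc2)C1c1ccc(Br)cc1)c1ccccc1` differs from compound 3 by iodo in place of hydrogen on an aromatic carbon. Among the compounds with values here, no measured step alters the anilino ring itself. The two steps that exchange the whole group at that ring carbon, a 1.3-fold lower number from compound 1 to compound 3 (0.11 log units; within the scatter) and a 1.1-fold higher number from compound 2 to compound 3 (0.03 log units; within the scatter), both stayed within the scatter, so this position has so far accepted change without a step beyond the scatter. On that basis no step beyond the scatter is expected in this assay. Compound 4 is expected at 24000 nM, with a range from 10000 nM to 55000 nM. The expected step is a 1.0-fold lower number from compound 3 to compound 4 (0.01 log units; within the scatter).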

Compound 4, half-maximal inhibitory concentration: 23400 nM
For compound 4 the middle estimate is 1.0-fold (0.01 log units) above the measured one, within the range that was stated.
By their numbers in this assay, from the lowest: compounds 2, 4, 3 and 1 (each within the scatter of the next).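

In this assay a change on the anilino ring itself, iodo in place of hydrogen para to a large group, gives a 1.0-fold lower number from compound 3 to compound 4 (0.02 log units; within the scatter) and so leaves this aromatic carbon without a step beyond the scatter. The (4-iodophenyl)amino group also stays within the scatter of the other two groups at the double-bonded ring carbon, with a 1.0-fold higher number from compound 2 to compound 4 (0.01 log units; within the scatter) against isopropoxy and a 1.4-fold lower number from compound 1 to compound 4 (0.13 log units; within the scatter) against hydroxy, so the four compounds remain unseparated. Nothing at hand accounts for this flat picture.

Going by these compounds, whether it holds for an amine or a carboxylic acid at the same aromatic carbon stays open, as does iodo at another carbon of that ring. Also open, on these data alone, is whether a longer chain in place of the anilino group, or a change elsewhere on the shared core, would give any step beyond the scatter in this assay at all.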